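The source may hold more compounds than are shown below. What is called first, only, known or untested is meant among the compounds shown, and "the series" means these compounds.

Compound 1, `N#Cc1ccccc1-c1cnc(C(=O)CCCCCCc2ccccc2)o1`, gives 130 nM in an assay (Rattus norvegicus) for inhibition of Fatty-acid amide hydrolase 1 (Homo sapiens); a lower number here means a stronger inhibitor, a higher number a weaker inhibitor.
Compound 2, `Nc1ccc(-c2cnc(C(=O)CCCCCCc3ccccc3)o2)cc1`, gives 90 nM in this assay.
Compound 3, `O=C(CCCCCCc1ccccc1)c1ncc(I)o1`, gives 3 nM in this assay.

Compound 3 holds the lowest number of the three and is the strongest inhibitor shown: the move to it from the aryl-bearing compounds was large in both cases, a 43-fold lower number from compound 1 to compound 3 (1.64 log units; beyond the scatter) and a 30-fold lower number from compound 2 to compound 3 (1.48 log units; beyond the scatter), whereas the two aryl compounds lie within the scatter of each other, a 1.4-fold lower number from compound 1 to compound 2 (0.16 log units; within the scatter). Compound 4, `CSc1cnc(C(=O)CCCCCCc2ccccc2)o1`, has not yet been measured. It differs from compound 3 in one place: methylsulfanyl in place of iodo on an aromatic carbon.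

Among the compounds with values here, no measured step replaces iodo with a group of this kind. Within the data shown here, the steps that bear on the change only show that a small iodo on this ring position gives far lower numbers than either aryl group, so the ring carbon tolerates, and seems to favour, a small substituent. Methylsulfanyl is also small, but it is not the iodo that gave the best number, and the expected outcome is a moderate rise from compound 3 rather than a return to the aryl range, a 6.7-fold higher number from compound 3 to compound 4 (0.82 log units; beyond the scatter). Compound 4 is therefore estimated at 20 nM, with a range from 4 nM to 100 nM.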

Compound 4, inhibition constant: 25 nM
Estimate against measurement, compound 4: 1.3-fold (0.10 log units) below; the range from low to high includes it.
By their numbers in this assay, from the lowest: compound 3; then compound 4; then compounds 2 and 1 (each within the scatter of the next).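

In this assay, the change at this ring carbon, next to the ring oxygen, is not neutral among non-aryl groups: an 8.3-fold higher number from compound 3 to compound 4 (0.92 log units; beyond the scatter), so the low number of compound 3 does not extend in full to every small substituent placed there. Methylsulfanyl nevertheless keeps a clear advantage over both aryl groups, with a 3.6-fold lower number from compound 2 to compound 4 (0.56 log units; beyond the scatter) and a 5.2-fold lower number from compound 1 to compound 4 (0.72 log units; beyond the scatter), which places compound 4 between compound 3 and the two aryl compounds and shows that the gain seen with iodo is partly retained by a quite different atom set. Nothing available accounts for the gap between iodo and methylsulfanyl, so the result stands here as an observed order without an explanation.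

The compounds shown leave open where other groups at this ring carbon would fall in that order, such as chloro, methyl, methoxy, an amine or a carboxylic acid. They also leave open whether the same order would hold with a longer or shorter chain between the carbonyl and the phenyl ring, since all four compounds share one chain.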